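Cycloheptyl in Place of an Aromatic Ring on the Amine

A few compounds are considered here, and "the series" means these few. Any claim that something is new, unique, unknown or untested is made for them only; others in the source may bear on it.

Compound 1 `Nc1scc(CN2CCN(c3ccc(Cl)cc3Cl)CC2)c1C(=O)c1ccc(Cl)cc1` and compound 2 `Nc1scc(CN2CCN(c3ccccc3C(F)(F)F)CC2)c1C(=O)c1ccc(Cl)cc1` share one core and differ only in the group carried on an amine nitrogen in a ring. In an assay on CHO cells for displacement of a labelled ligand from adenosine receptor A3 (Homo sapiens), read by scintillation counting, with a stated time of 120 min, tested at 10 uM (a lower number here means less inhibition, a higher number more inhibition at the concentration tested (going by the name of the read-out)), compound 1 gives 0% and compound 2 gives 0%. The step of no change at the digits printed from compound 1 to compound 2 (within the scatter) shows that trading one aromatic group for another moved nothing, so compound 2 stands level with compound 1 at the digits recorded, both at the floor of the read-out.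

Compound 3 `Nc1scc(CN2CCN(C3CCCCCC3)CC2)c1C(=O)c1ccc(Cl)cc1` introduces the change (cycloheptyl in place of 2-(trifluoromethyl)phenyl on an amine nitrogen in a ring). Among the measured compounds shown here, only one measured step touches this position, no change at the digits printed from compound 1 to compound 2 (within the scatter), and it was flat; yet that step kept a six-membered aromatic ring, whereas here a seven-membered non-aromatic ring enters, so it guides only loosely. Since both measured compounds sit at the floor, a step beyond the scatter can only go upward, and the expected step of a number 5 percentage points higher from compound 2 to compound 3 (within the scatter) is small. Compound 3 is therefore expected to give 5%, with a range from 0% to 25%.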

Compound 3, a percentage reported as inhibition, at one concentration (the size of the read-out at that concentration, not a potency): 0%
For compound 3 the middle estimate is 5 percentage points above the measured one, and the stated range covers the measured number.
By their numbers in this assay, from the lowest: compounds 1, 2 and 3 (each within the scatter of the next).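

In this assay the exchange of an aromatic ring for a saturated one gives no change at the digits printed from compound 2 to compound 3 (within the scatter) and the comparison with the dichlorinated group gives no change at the digits printed from compound 1 to compound 3 (within the scatter), so the flat result on the amine nitrogen in a ring is no longer limited to one six-membered aromatic ring replacing another. Cycloheptyl, a seven-membered non-aromatic ring of carbon only, also leaves the read-out at zero, which means all three groups tried at this position, aromatic or not, sit together at the bottom of the scale and cannot be ranked against one another. Nothing measured here offers an explanation for this flat result.

Going by these compounds, all three compounds share the core and the 4-chlorophenyl ketone, so it remains open whether any group on this nitrogen can lift the read-out above zero, for example a short chain ending in a carboxylic acid, a benzyl group or a pyridine ring. On these data alone, it also remains open whether changing another part of the core, such as the free amine on the thiophene-like ring's carbon, would matter more than this position.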